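From compound 2 to compound 4 in cell inhibition

The source may hold more compounds than are shown below. What is called first, only, known or untested is meant among the compounds shown, and "the series" means these compounds.

Compound 1 `O=C(O)C1=Cc2ccccc2OC1(OCc1cc(-c2ccc(F)cc2)no1)C(F)(F)F`: > 150000 nM
Compound 2 `CCOC(=O)C1=Cc2ccccc2OC1(OCc1cn(-c2ccc(C)cc2)nn1)C(F)(F)F`: 19700 nM
Compound 3 `O=C(O)C1=Cc2ccccc2OC1(OCc1cc(-c2ccc(F)cc2F)no1)C(F)(F)F`: > 150000 nM

In a functional assay on A549 cells (Homo sapiens) for inhibition, read by MTT assay, with a stated time of 24 h (on this read-out higher numbers stand for weaker inhibition and lower numbers for stronger inhibition), compound 1 reaches only a limit of the assay, > 150000 nM. Compound 3 likewise gives only a limit, > 150000 nM. The step from one to the other, a step that the two limits leave unreadable from compound 1 to compound 3, cannot be read because of the limit of > 150000 nM in this assay, at which 2 of the 3 values shown sit. Going by the values given here, compound 2 gives 19700 nM, the only number among the three values shown, so it is the sole anchor for anything that follows.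

Compound 4 `CCOC(=O)C1=Cc2ccccc2OC1(OCc1cn(-c2ccc(F)c([N+](=O)[O-])c2)nn1)C(F)(F)F` has not yet been measured in this assay. It differs from compound 2 in one place: 4-fluoro-3-nitrophenyl in place of 4-methylphenyl on an aromatic nitrogen. No measured step touches this change, and the one step that is shown is unreadable, so there is no basis for expecting a shift beyond the scatter in either direction. Compound 4 is therefore expected to give 20000 nM, with a range from 5000 nM to 80000 nM. The step this estimate means is expected to be a 1.0-fold higher number from compound 2 to compound 4 (0.01 log units; within the scatter).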

Compound 4, half-maximal inhibitory concentration: 11900 nM
Estimate against measurement, compound 4: 1.7-fold (0.23 log units) above, within the range that was stated.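

Exchanging 4-methylphenyl for 4-fluoro-3-nitrophenyl on the aromatic nitrogen gives, in this assay, a 1.7-fold lower number from compound 2 to compound 4 (0.22 log units; within the scatter), the only readable step among the compounds shown. The entering group brings a nitro group, a fluorine and hydrogen-bond acceptors that the leaving group lacks, yet the two values stay within the scatter of each other. For this pair, then, the substitution on the aromatic ring attached at this nitrogen does not separate the two compounds in the read-out.

Going by these compounds, the step from compound 1 to compound 3 cannot be read because both compounds sit at a limit of the assay: the limit of > 150000 nM in this assay, at which 2 of the 4 values shown sit. It remains open whether an amine, a nitrile or a longer chain on that aromatic ring would move the number beyond the scatter.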